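A few compounds are considered here, and "the series" means these few. Any claim that something is new, unique, unknown or untested is made for them only; others in the source may bear on it.

In a functional assay on MCF7 cells (Homo sapiens) for antiproliferative activity, read by MTT assay (on this read-out higher numbers stand for weaker inhibition and lower numbers for stronger inhibition), compound 1 (`CCCCC/C=C\C/C=C\CCCCCCCc1cc(=O)c2c(O)c(C)c(OCOC)cc2o1`) gives > 67200 nM, which is a limit and not a number. Compound 2 (`CCCCC/C=C\C/C=C\CCCCCCCc1cc(=O)c2c(O)c(C)c(O)cc2o1`), with hydrogen in place of methoxymethyl on an oxygen on an aromatic ring, gives > 84100 nM, which is also a limit. Compound 3 (`CCCCCCCCCCCCCCCc1cc(=O)c2c(O)c(C)c(O)cc2o1`) differs from compound 2 in its chain: octyl in place of deca-1,4-dien-1-yl on a saturated chain carbon, seven bonds along the chain from an aromatic carbon. Within the data shown here, the only measured step, a step that the two limits leave unreadable from compound 1 to compound 2, has no readable size to carry over, so no change beyond the scatter is expected in this assay. The expected step is a step that the limit leaves unreadable from compound 2 to compound 3. For compound 3 the estimated value is 85000 nM, with a range of 40000 nM to 150000 nM.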

Compound 3, half-maximal inhibitory concentration: 43200 nM
Beside the measured number, compound 3's estimate is 2.0-fold (0.29 log units) above it; the measured number falls inside the stated range.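

Octyl in place of deca-1,4-dien-1-yl on this saturated chain carbon gives the first readable number in this assay, with an at least 1.9-fold lower number from compound 2 to compound 3 (0.28 log units; that floor lies within the scatter) as the step. Only a floor can be stated for this step, and it stays within the scatter, because compound 2 stands at a limit and not at a number: the limit of > 84100 nM in this assay, at which 1 of the 3 values shown sits. The step from compound 1 to compound 2 cannot be read.

As far as these compounds go, whether the double bonds or the chain length carries the step stays open. From the compounds shown here alone, what a saturated decyl group or a longer chain would give here also stays open.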